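A few compounds are considered here, and "the series" means these few. Any claim that something is new, unique, unknown or untested is made for them only; others in the source may bear on it.

Working notes on the urea series. Compound 1, `CCOc1nc(Cl)cc(NC(=O)NCc2cc(C)c(-c3cn(C)nc3C(F)(F)F)nn2)c1C`, carries the core that the other members vary. In an ADME assay on microsomes from liver (Homo sapiens) for metabolic stability, read by LC-MS, with a stated time of 4 h, tested at 1 uM (on this read-out higher numbers stand for fast clearance and lower numbers for slow clearance), compound 1 gives < 127 mL/min/kg, which is a limit of the assay and not a number. Compound 2, `CCOc1nc(C#N)cc(NC(=O)NCc2cc(C)c(-c3cn(C)nc3C(F)(F)F)nn2)c1C`, differs from compound 1 by cyano in place of chloro on an aromatic carbon. In this assay compound 2 gives < 35 mL/min/kg, again a limit of the assay rather than a number. The step that the two limits leave unreadable from compound 1 to compound 2 therefore cannot be sized. the limit of < 127 mL/min/kg in this assay, at which 1 of the 3 values shown sits, is one of the two bounds concerned. the limit of < 35 mL/min/kg in this assay, at which 1 of the 3 values shown sits, is the other. Compound 3, `CCOc1nc(C)cc(NC(=O)NCc2cc(C)c(-c3cn(C)nc3C(F)(F)F)nn2)c1Cl`, holds the same atoms as compound 1 joined differently: 3-chloro-2-ethoxy-6-methylpyridin-4-yl in place of 6-chloro-2-ethoxy-3-methylpyridin-4-yl on an amide-type nitrogen. In this assay compound 3 gives < 25 mL/min/kg, also a limit of the assay. The step that the two limits leave unreadable from compound 1 to compound 3 is likewise not readable. the limit of < 25 mL/min/kg in this assay, at which 1 of the 3 values shown sits, is the bound that closes it off. No ordering among the three compounds can be drawn from these values; each rests at its own limit.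

Compound 4, `CCOc1nc(C)cc(NC(=O)NCc2cc(C)c(-c3cn(C)nc3C(F)(F)F)nn2)c1C#N`, is not yet measured in this assay. It differs from compound 3 by cyano in place of chloro on an aromatic carbon. This is the same kind of change as that from compound 1 to compound 2, but not the same: in compound 2 the cyano sits next to the ring nitrogen, meta to a large group and meta to an ethoxy group, whereas in compound 4 it sits two atoms from the ring nitrogen, ortho to a large group and ortho to an ethoxy group. The earlier step, a step that the two limits leave unreadable from compound 1 to compound 2, offers no readable size to lean on. The expected step that the limit leaves unreadable from compound 3 to compound 4 is small, resting on compound 3 with < 25 mL/min/kg and on compound 2 with < 35 mL/min/kg, both of them limits. Compound 4 is estimated at 15 mL/min/kg, expected to fall between 5 mL/min/kg and 40 mL/min/kg, with a fair chance that the assay again returns only a limit.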

Compound 4, clearance: > 500000 mL/min/kg
Compound 4: a limit, no number; the forecaster's own chance of this, stated with the estimate: 60%; at least 33000-fold (4.52 log units) between middle value and limit.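

In this assay, cyano in place of chloro on the core of compound 3, ortho to a large group, ortho to an ethoxy group and two atoms from the ring nitrogen, gives an at least 20000-fold higher number from compound 3 to compound 4 (4.30 log units; beyond the scatter). Compound 4 stands at a limit of the assay and not at a number: the limit of > 500000 mL/min/kg in this assay, at which 1 of the 4 values shown sits. Compound 2, which carries cyano at another place on the ring, gives < 35 mL/min/kg, also a limit, and the steps that start from compound 1 cannot be read, so the large step rests on a single pair and shows neither that the change carries to another core nor that it fails to.

The compounds shown leave open whether the large step goes with cyano as such or with this one place on this core, and no value in this assay among the four compounds is a readable number. An amine or a carboxylic acid on that same aromatic carbon, or a longer chain in place of the ethoxy group, lies outside the compounds shown, so how the read-out responds to such groups remains unknown.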